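The source may report more compounds than this note shows. Statements on the series, on what has been measured and on what is new or still open speak of the compounds shown alone.

Compound 3, `NNCc1cc(O)n2nc(N)c([N+](=O)[O-])c2n1`, is the only one of the three measured compounds to give a number in a functional assay on K562 cells (Homo sapiens) for inhibition; a lower number here means a stronger inhibitor of growth, a higher number a weaker inhibitor of growth: compound 3 gives 26.5 ug/mL. Compound 1, `Nc1nn2c(O)cc(-c3ccccc3F)nc2c1[N+](=O)[O-]`, reaches only the limit of the assay, and compound 1 gives > 50 ug/mL in this assay. Compound 2, `Nc1nn2c(O)cc(-c3ccc(F)cc3)nc2c1[N+](=O)[O-]`, likewise reaches only a limit, and compound 2 gives > 50 ug/mL in this assay. Two of the three values therefore sit at the limit of > 50 ug/mL in this assay, at which 2 of the 3 values shown sit. The step of an at least 1.8-fold lower number from compound 1 to compound 3 (0.27 log units; that floor lies within the scatter) and the step of an at least 1.8-fold lower number from compound 2 to compound 3 (0.27 log units; that floor lies within the scatter) both point the same way, but each is a floor that lies within the scatter, so they give only a weak hint of direction.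

Compound 4, `Nc1nn2c(O)cc(CNNC(N)S)nc2c1[N+](=O)[O-]`, is not yet measured. It differs from compound 3 in one place: amino(sulfanyl)methyl in place of hydrogen on an amine nitrogen. Among the measured compounds shown here, no measured step touches that position, so the measured steps bear on it only in showing how little this series has moved. Compound 4 is therefore expected to stay near compound 3, with a step of a 1.1-fold higher number from compound 3 to compound 4 (0.05 log units; within the scatter) that is within the scatter, and its estimated value is 30 ug/mL, between 12 ug/mL and 50 ug/mL.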

Compound 4, concentration for 50% growth inhibition: > 50 ug/mL
Compound 4: a limit, no number (the forecaster's own chance of this, stated with the estimate: 35%); middle value at least 1.6-fold (0.22 log units) from the limit.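

Among the compounds shown here, the amine nitrogen of the (aminoamino)methyl group was untouched by any earlier step, and amino(sulfanyl)methyl placed there gives the first reading for this position in this assay: an at least 1.8-fold higher number from compound 3 to compound 4 (0.27 log units; that floor lies within the scatter). This points towards weaker growth inhibition, but only as a weak hint, not as a proven loss. The steps from compound 1 and from compound 2 to compound 4 cannot be read, because both ends of each sit at one limit: the limit of > 50 ug/mL in this assay, at which 3 of the 4 values shown sit.

As far as these compounds go, how far compound 4 truly lies from compound 3 stays open, since only a limit is available for compound 4. Also open, from the compounds shown here alone, is how other groups on this amine nitrogen would read, such as a methyl, an acetyl or a chain ending in a carboxylic acid, and whether the sulfur atom of amino(sulfanyl)methyl plays any part.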